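Swapping a Ring Amine for a Cyclohexyloxy Group

The source may hold more compounds than are shown below. What is called first, only, known or untested is meant among the compounds shown, and "the series" means these compounds.

Compound 1, `CC(C(=O)NCc1ccc(C(F)(F)F)cc1N1CCCCCCC1)c1ccc(NS(C)(=O)=O)c(F)c1`: 2.8 nM
Compound 2, `COc1ccc(N2CCN(c3cc(C(F)(F)F)ccc3CNC(=O)C(C)c3ccc(NS(C)(=O)=O)c(F)c3)CC2)cc1`: 1.6 nM

Of the compounds shown here, two have been measured in an assay on CHO cells for antagonist activity at transient receptor potential cation channel subfamily V member 1 (Homo sapiens), read by FLIPR; a lower number here means a stronger inhibitor, a higher number a weaker inhibitor. Compound 1 gives 2.8 nM and compound 2 gives 1.6 nM; these two numbers lie within the usual scatter of each other, so on the numbers shown compound 1 cannot be told apart from compound 2, and no ordering between them is claimed.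

Compound 3, `CC(C(=O)NCc1ccc(C(F)(F)F)cc1OC1CCCCC1)c1ccc(NS(C)(=O)=O)c(F)c1`, has not yet been measured. It keeps the shared core of compound 1 and differs in one place: a group of 7 heavy atoms (6 carbon, 1 oxygen; one six-membered non-aromatic ring of carbon only) in place of a group of 8 heavy atoms (7 carbon, 1 nitrogen; one eight-membered non-aromatic ring with 1 hetero atom), on an aromatic carbon.

Going by the values given here, no measured pair shows what such a swap does in this assay, so the step has to be guessed from the structures alone. Both groups are of similar size and neither adds a donor, so the step from compound 1 to compound 3 is expected to be small, possibly a modest weakening, and the expected size is a 2.1-fold higher number from compound 1 to compound 3 (0.33 log units; beyond the scatter). Compound 3 is therefore estimated at 6 nM, with a range from 1.5 nM to 25 nM.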

Compound 3, inhibition constant: 0.7 nM
For compound 3 the middle estimate is 8.6-fold (0.93 log units) above the measured one; measured number below the stated range.
By their numbers in this assay, from the lowest: compound 3; then compounds 2 and 1 (each within the scatter of the next).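

Measured in this assay the swap of the eight-membered nitrogen ring for cyclohexyloxy, on an aromatic carbon meta to a trifluoromethyl group, gives a 4.0-fold lower number from compound 1 to compound 3 (0.60 log units; beyond the scatter) and so is a real change rather than scatter. This position therefore does not depend on a ring joined through nitrogen, as a ring joined through oxygen is accepted here and gives the lower number. The two earlier compounds both carry a nitrogen-joined ring and cannot be told apart, so they could not show this.

Nothing measured here explains the drop. The linking atom and the ring size change together in this one step, and a piperidine ring or a cyclooctyloxy group at the same place would pull the two apart.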